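Same Swap, Different Ring: Trifluoromethyl for Methyl

The compounds below may be only part of what the source reports. "The series", "measured", "known", "first", "only" and "open" are said of these compounds alone.

Of the compounds shown here, three built around an aminoquinazoline-type scaffold have been measured in an assay for inhibition of high affinity nerve growth factor receptor (Homo sapiens), read by HTRF, with a stated time of 30 min, in the presence of a further agent that is not named here; on this read-out lower numbers stand for stronger inhibition and higher numbers for weaker inhibition. Compound 1 `Cc1ccc(CNc2nc(Nc3cc(C)[nH]n3)c3ccccc3n2)cc1` gives 110 nM. Compound 2 `Cc1cc(Nc2nc(NCc3ccc(C(F)(F)F)cc3)nc3ccccc23)n[nH]1`, which carries a trifluoromethyl in place of methyl on an aromatic carbon, gives 1400 nM. The change trifluoromethyl in place of methyl on an aromatic carbon thus brought a 13-fold higher number from compound 1 to compound 2 (1.10 log units; beyond the scatter). Compound 3 `Cc1ccc2nc(NCc3ccc(F)cc3F)nc(Nc3cc(C)[nH]n3)c2c1` gives 110 nM, level with compound 1 at the digits shown; the difference between the two cores of compound 1 and compound 3 is not broken down here.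

Compound 4 `Cc1cc(Nc2nc(NCc3ccc(F)cc3F)nc3ccc(C(F)(F)F)cc23)n[nH]1` has not yet been measured in this assay. Relative to compound 3 it carries the change (trifluoromethyl in place of methyl on an aromatic carbon). This is the same kind of change as that from compound 1 to compound 2, but not the same: in compound 2 the new group sits on a six-membered aromatic ring of carbon only, para to a large group, whereas in compound 4 it sits on a ring that is part of a fused or bridged system of two rings, meta to a fused ring and para to a fused ring.

Only one earlier instance of this swap exists among these compounds, and it lies on a different ring. Compound 4 is therefore expected to show a weaker step, a 3.2-fold higher number from compound 3 to compound 4 (0.50 log units; beyond the scatter), than the step of a 13-fold higher number from compound 1 to compound 2 (1.10 log units; beyond the scatter), with wide uncertainty. The estimate for compound 4 in this assay is 350 nM, expected to fall between 110 nM and 1500 nM.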

Compound 4, half-maximal inhibitory concentration: 370 nM
For compound 4 the middle estimate is 1.1-fold (0.02 log units) below the measured one, within the range that was stated.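

Trifluoromethyl in place of methyl on an aromatic carbon again moved the number upward in this assay, giving a 3.4-fold higher number from compound 3 to compound 4 (0.53 log units; beyond the scatter), so on both cores shown the change went in the same direction and weakened inhibition. The size of the step did not carry over from one core to the other: the same change on two cores in this assay, a 13-fold higher number (1.10 log units; beyond the scatter) from compound 1 to compound 2 and a 3.4-fold higher number (0.53 log units; beyond the scatter) from compound 3 to compound 4, 3.8-fold (0.58 log units) apart, beyond the scatter of two such steps Two pairs cannot show what sets that size: in compound 4 the new group sits on a ring that is part of a fused or bridged system of two rings, while in compound 2 it sits on a different ring, and the rest of the two molecules also differs, so the gap cannot be assigned to any one of these differences, and no rule for a further core follows from it.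

The compounds shown leave open how other groups in the same place, such as a chlorine, a nitrile or a methoxy, would compare with methyl and trifluoromethyl on either core. They also leave open what size of step the same swap would give if it were made on the ring that carries it in compound 2 while the rest of the molecule stayed that of compound 3.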